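Swapping an Aminophenyl Group for a Methylphenyl Group

The source may report more compounds than this note shows. Statements on the series, on what has been measured and on what is new or still open speak of the compounds shown alone.

Measured in a functional assay on MCF7 cells (Homo sapiens) for inhibition, read by trypan blue exclusion, with a stated time of 3 days; a higher number here means a weaker inhibitor, a lower number a stronger inhibitor:
Compound 1 `COc1cc(C(=O)c2cn(-c3cccc(C)c3)cc2-c2ccccc2)cc(OC)c1OC`: 120 nM
Compound 2 `COc1cc(C(=O)c2cn(-c3cccc(N)c3)cc2-c2ccccc2)cc(OC)c1OC`: 74 nM

Among the measured compounds shown here, with a value of 74 nM, compound 2 cannot be told apart from the only other measured compound, since the two values lie within the usual scatter of repeated measurements. That single measured step, a 1.6-fold lower number from compound 1 to compound 2 (0.21 log units; within the scatter), is therefore too small to read as a real difference.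

The next compound, compound 3 `COc1cc(C(=O)c2cn(-c3ccc(C)cc3)cc2-c2ccccc2)cc(OC)c1OC`, has not yet been measured. The change is 4-methylphenyl in place of 3-aminophenyl on an aromatic nitrogen. For the measured compounds named here, no measured compound carries a 4-methylphenyl group, so the evidence is thin. The nearest guide is compound 1, at 120 nM, which has a methyl group where the other measured compound has its amino group. Going by the values given here, on that basis, no step clearly beyond the scatter is expected in this assay, with at most a slightly higher number. The estimated step is a 1.8-fold higher number from compound 2 to compound 3 (0.24 log units; within the scatter). The estimate for compound 3 is 130 nM, with an expected range from 45 nM to 380 nM.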

Compound 3, half-maximal inhibitory concentration: 30 nM
Compound 3: the middle estimate sits 4.3-fold (0.64 log units) above what was measured; the measured number lies below the stated range.
By their numbers in this assay, from the lowest: compound 3; then compounds 2 and 1 (each within the scatter of the next).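

In this assay the change from 3-methylphenyl to 4-methylphenyl on the aromatic nitrogen gives a 4.0-fold lower number from compound 1 to compound 3 (0.60 log units; beyond the scatter) and so shows that the place of the methyl group on this phenyl ring counts. Among the compounds shown here, earlier, amino and methyl at the same ring place could not be told apart, so this is the first change at this position to give a step beyond the scatter. The change from 3-aminophenyl to 4-methylphenyl gives a 2.5-fold lower number from compound 2 to compound 3 (0.39 log units; beyond the scatter) as well, but it alters both the group and its place on the ring, so this step alone cannot separate the two changes, and nothing measured here explains why the place of the methyl group matters.

A 4-aminophenyl group on the same nitrogen would show whether the amino group follows the methyl group in this shift, and a 2-methylphenyl group would complete the set of ring places for methyl. Groups such as 4-ethylphenyl or 4-methoxyphenyl remain open too, so it is unknown whether the lower number belongs to methyl itself or to other groups at that ring place.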